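A few compounds are considered here, and "the series" means these few. Any claim that something is new, unique, unknown or untested is made for them only; others in the source may bear on it.

The set is three compounds on one shared core. In a functional assay on RPMI-8226 cells (Homo sapiens) for inhibition, read by sulforhodamine B assay, with a stated time of 48 h (a lower number here means that less compound is tolerated, a higher number that more compound is tolerated), compound 1 `O=C(Nc1cccc(-n2cc(-c3ccncc3)c(-c3ccc(Cl)c(O)c3)n2)c1)Nc1cccc(C(F)(F)F)c1` reaches only a limit of the assay, > 32500 nM. Compound 2 `COc1cc(-c2nn(-c3cccc(NC(=O)c4cccc(C(F)(F)F)c4)c3)cc2-c2ccncc2)ccc1Cl` likewise stops at a limit, > 50000 nM. Compound 3 `O=C(Nc1cccc(-n2cc(-c3ccncc3)c(-c3ccc(Cl)c(O)c3)n2)c1)Nc1cc(C(F)(F)F)cc(C(F)(F)F)c1` also returns a limit, > 50000 nM. The step that the two limits leave unreadable from compound 1 to compound 3 therefore cannot be sized, since every value sits at a limit, namely the limit of > 32500 nM in this assay, at which 1 of the 3 values shown sits, and (the limit of > 50000 nM in this assay, at which 2 of the 3 values shown sit). Compound 4 `O=C(Nc1cccc(-n2cc(-c3ccncc3)c(-c3ccc(Cl)c(O)c3)n2)c1)Nc1ccc(Cl)c(C(F)(F)F)c1` differs from compound 1 by chloro in place of hydrogen on an aromatic carbon. Within the data shown here, no measured step bears on this change; the single available step is unreadable. Compound 4 is therefore expected to remain at a limit as well, with an estimated step that the limit leaves unreadable from compound 1 to compound 4 amounting to none beyond the scatter. The estimate for compound 4 is 50000 nM, expected within 20000 nM to 120000 nM.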

Compound 4, concentration lethal to 50% of the cells: > 32500 nM
Compound 4 gave a limit, no number; the forecaster's own chance of this, stated with the estimate: 75%; the middle value lies beyond the limit too.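

In this assay compound 4 gives > 32500 nM, a limit, so its step from compound 1 cannot be read. The compounds shown leave open whether any change on the shared core gives a readable lethal concentration.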